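Allyloxy to Ethyl on the Sulfur-Bound Carbonyl

The source may report more compounds than this note shows. Statements on the series, on what has been measured and on what is new or still open speak of the compounds shown alone.

Among the measured compounds shown here, compound 1 `C=CCOC(=O)SCCCCCCNC(=O)c1cc(-c2ccncc2)n[nH]1` is the only member of this small set with a numerical result: in a functional assay on HCT-116 cells (Homo sapiens) for inhibition, read by MTT assay, with a stated time of 96 h (on this read-out lower numbers stand for stronger inhibition of growth and higher numbers for weaker inhibition of growth), compound 1 gives 32900 nM. Its two companions carry a different aromatic substituent on the shared core and end differently. Compound 2 `O=C(NCCCCCCS)c1cc(-c2ccc3ccccc3c2)n[nH]1` reaches only the limit of the assay, returning > 50000 nM in this assay. Compound 3 `O=C(NCCCCCCS)c1cc(-c2cccc3ccccc23)n[nH]1` likewise stops at the limit, returning > 50000 nM in this assay. Thus the set shows (the limit of > 50000 nM in this assay, at which 2 of the 3 values shown sit), and no step between measured compounds that differ in one place exists, so compound 1 stands alone as the sole number against two limits.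

The untested compound 4 `CCC(=O)SCCCCCCNC(=O)c1cc(-c2ccncc2)n[nH]1` differs from compound 1 in a single place: ethyl in place of allyloxy on a carbonyl carbon. The rest of the molecule, including the shared core and the sulfur that neighbours the changed carbonyl carbon, is untouched.

For the measured compounds named here, with no measured step to lean on, the expectation is a step no larger than the usual scatter, a 1.5-fold lower number from compound 1 to compound 4 (0.17 log units; within the scatter), leaning slightly toward stronger inhibition in this assay. Compound 4 is therefore estimated at 22000 nM, between 7000 nM and 60000 nM, with some chance that the assay returns only a limit.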

Compound 4, concentration for 50% growth inhibition: > 50000 nM
Compound 4 was reported as a limit (the forecaster's own chance of this, stated with the estimate: 25%); at least 2.2-fold (0.35 log units) between middle value and limit.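

Among the compounds shown here, the swap of allyloxy for ethyl on a carbonyl carbon whose other neighbour is sulfur gives the first readable step in this set in this assay (an at least 1.5-fold higher number from compound 1 to compound 4 (0.18 log units; that floor lies within the scatter)), but this is only a floor, and the true size of the step stays unknown. Compound 4 returns a limit of the assay and not a number (> 50000 nM). For the compounds shown here, the result shows that this position does not keep a measurable number once ethyl, with fewer heavy atoms and no hydrogen-bond acceptor, takes the place of allyloxy, and compound 1 remains the only compound with a number, while the rest of the set now gathers at one ceiling: (the limit of > 50000 nM in this assay, at which 3 of the 4 values shown sit).

What the compounds shown leave open is whether the oxygen of allyloxy or its double bond matters here, since a methoxy, an ethoxy or an allyl group on the same carbonyl carbon would separate the two. Going by these compounds, an amine on that carbonyl carbon, or a longer chain in place of ethyl, is also absent from these compounds, so the reach of this position in the assay remains unknown.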